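Aminopyrimidine-nitrile series: anilino swap from compound 2

The source may report more compounds than this note shows. Statements on the series, on what has been measured and on what is new or still open speak of the compounds shown alone.

Two compounds of the shared core carry numbers in a functional assay on MCF7 cells (Homo sapiens) for inhibition, read by MTT assay, with a stated time of 72 h; on this read-out lower numbers stand for stronger inhibition and higher numbers for weaker inhibition. Compound 2 `COc1ccccc1Nc1nc(SCc2cn(CC(=O)NC(=O)Nc3ccccn3)nn2)nc(-c2ccc(C)cc2)c1C#N` gives 19700 nM in this assay. Compound 1 `COc1cc(-c2nc(SCc3cn(CC(=O)NC(=O)Nc4ccccn4)nn3)nc(Nc3cccc(Cl)c3)c2C#N)cc(OC)c1OC` gives 24000 nM in this assay, and the two numbers sit within the usual scatter of each other, so compound 2 does not stand apart from compound 1 on what has been measured. Compound 3 `Cc1ccc(-c2nc(SCc3cn(CC(=O)NC(=O)Nc4ccccn4)nn3)nc(Nc3cccc(Cl)c3)c2C#N)cc1` is not yet measured. It differs from compound 2 in one place: 3-chlorophenyl in place of 2-methoxyphenyl on a nitrogen on an aromatic ring. Within the data shown here, no measured pair shows this change on its own, so its size is unknown. Compound 1 already carries the (3-chlorophenyl)amino group with a different aryl partner and lands near compound 2, which gives no sign of a large effect. For compound 3 no step beyond the scatter is expected, in either direction, with an expected step of a 1.1-fold higher number from compound 2 to compound 3 (0.05 log units; within the scatter). Compound 3 is therefore estimated at 22000 nM in this assay, within 8000 nM to 60000 nM.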

Compound 3, half-maximal inhibitory concentration: 14900 nM
For compound 3 the middle estimate is 1.5-fold (0.17 log units) above the measured one; measured number inside the range.
By their numbers in this assay, from the lowest: compounds 3, 2 and 1 (each within the scatter of the next).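

In this assay, the swap of 3-chlorophenyl in place of 2-methoxyphenyl on a nitrogen on an aromatic ring now has a measured size, a 1.3-fold lower number from compound 2 to compound 3 (0.12 log units; within the scatter), so this pair does not tell the two groups apart. Compound 3 also gives a first reading on the aryl partner with the (3-chlorophenyl)amino group held fixed: 4-methylphenyl in place of 3,4,5-trimethoxyphenyl on an aromatic carbon reads a 1.6-fold lower number from compound 1 to compound 3 (0.21 log units; within the scatter), so neither place has yet shown a step beyond the scatter. Nothing at hand offers an explanation for these readings.

Each swap is seen only once, against a single partner at the other place, so neither reading is known to carry over to other partners. On these data alone, whether a piperidine or a carboxylic acid at either place would give a step beyond the scatter remains open.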